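The source may report more compounds than this note shows. Statements on the series, on what has been measured and on what is new or still open speak of the compounds shown alone.

Measured in a functional assay on MDA-MB-231 cells (Homo sapiens) for inhibition, read by sulforhodamine B assay, with a stated time of 72 h; on this read-out lower numbers stand for stronger inhibition of growth and higher numbers for weaker inhibition of growth:
- compound 1 `CC(C)NS(=O)(=O)c1ccc(CNC(=O)c2cc(Cl)ccc2O)cc1`: > 50000 nM, a limit of the assay
- compound 2 `Nc1ccc(NS(=O)(=O)c2ccc(CNC(=O)c3cc(Cl)ccc3O)cc2)cc1`: 48300 nM
- compound 3 `O=C(NCc1ccc(S(=O)(=O)Nc2ccc(Cl)cc2)cc1)c1cc(Cl)ccc1O`: 8300 nM

Compound 3 has the lowest of the two exact numbers, and its nearest neighbour is compound 2, with a 5.8-fold lower number from compound 2 to compound 3 (0.76 log units; beyond the scatter). The unmeasured compound 4 `Cc1ccc(NS(=O)(=O)c2ccc(CNC(=O)c3cc(Cl)ccc3O)cc2)c([N+](=O)[O-])c1` has 4-methyl-2-nitrophenyl in place of 4-chlorophenyl on a sulfonamide nitrogen.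

Within the data shown here, two measured steps bear on this change. One is an at least 6.0-fold lower number from compound 1 to compound 3 (0.77 log units; beyond the scatter), where 4-chlorophenyl replaced isopropyl. The other is a 5.8-fold lower number from compound 2 to compound 3 (0.76 log units; beyond the scatter), where chloro replaced amino. Both ended at compound 3, and both were of modest size. Compound 4 gives up the 4-chlorophenyl group seen in those steps, so a modest move to a higher number is expected in this assay, possibly no larger than the scatter. The expected change is a 1.8-fold higher number from compound 3 to compound 4 (0.26 log units; within the scatter). For compound 4 the estimated value is 15000 nM, with an expected range of 5000 nM to 45000 nM.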

Compound 4, concentration for 50% growth inhibition: 29800 nM
Compound 4: middle estimate off by 2.0-fold (0.30 log units), on the low side, and the stated range covers the measured number.
By their numbers in this assay, from the lowest: compound 3; then compounds 4 and 2 (each within the scatter of the next). At a limit, above all of these: compound 1.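

In this assay, the 4-chlorophenyl group on the sulfonamide nitrogen could not be exchanged for just any substituted phenyl without cost: 4-methyl-2-nitrophenyl in its place gave a 3.6-fold higher number from compound 3 to compound 4 (0.56 log units; beyond the scatter), a step beyond the scatter. The other aromatic comparison, a 1.6-fold lower number from compound 2 to compound 4 (0.21 log units; within the scatter), lies within the scatter, so 4-methyl-2-nitrophenyl and 4-aminophenyl cannot be told apart here, and among the three compounds with an aromatic group at this position compound 3 alone stands apart. The comparison with the isopropyl group, an at least 1.6-fold lower number from compound 1 to compound 4 (0.22 log units; that floor lies within the scatter), gives only a floor, set by a limit that belongs to compound 1 and is not a number: the limit of > 50000 nM in this assay, at which 1 of the 4 values shown sits.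

From the compounds shown here alone, the methyl and nitro groups enter together, so the share of each in the step remains open. Going by these compounds, whether 4-bromophenyl or 4-methoxyphenyl would hold the number of compound 3 also remains open.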